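Aryl ether substituent and antagonist potency: series notes

The source may hold more compounds than are shown below. What is called first, only, known or untested is meant among the compounds shown, and "the series" means these compounds.

Compound 1, `Cc1cc(COc2ccccc2Cl)nc(-c2ccccn2)n1`, gives 316 nM in a functional assay on cells for antagonist activity at Free fatty acid receptor 1 (Homo sapiens), read by TR-FRET and inositol phosphate accumulation, with a stated time of 2 h; on this read-out higher numbers stand for weaker inhibition and lower numbers for stronger inhibition. Compound 2, `Cc1cc(COc2ccccc2S(C)(=O)=O)nc(-c2ccccn2)n1`, returns only the limit > 39800 nM in this assay, so no number is known for it. Going by the values given here, the one measured step, an at least 120-fold higher number from compound 1 to compound 2 (2.10 log units; beyond the scatter), runs up to the limit of > 39800 nM in this assay, at which 1 of the 2 values shown sits. Compound 3, `Cc1cc(COc2ccccc2F)nc(-c2ccccn2)n1`, differs from compound 2 by fluoro in place of methylsulfonyl on an aromatic carbon. Since compound 1, carrying chloro at the same place, gives 316 nM, a fluoro analogue is taken to sit near it. Compound 3 is therefore estimated at 500 nM, between 150 nM and 2000 nM. The expected step is an at least 79-fold lower number from compound 2 to compound 3 (1.90 log units; beyond the scatter).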

Compound 3, half-maximal inhibitory concentration: 398 nM
Beside the measured number, compound 3's estimate is 1.3-fold (0.10 log units) above it; the measured number falls inside the stated range.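

With a 1.3-fold higher number from compound 1 to compound 3 (0.10 log units; within the scatter) in this assay, fluoro and chloro on this aromatic carbon cannot be told apart. The much weaker result is therefore tied to methylsulfonyl rather than to chloro alone, as an at least 100-fold lower number from compound 2 to compound 3 (2.00 log units; beyond the scatter) restores a number of the same order with a second halogen. The value for compound 2 is a limit and not a number, so this step gives only a bound: the limit of > 39800 nM in this assay, at which 1 of the 3 values shown sits.

From the compounds shown here alone, it remains open whether methyl, methoxy or a nitrile at this place stays with the two halogens or moves towards methylsulfonyl. The same holds for an amine or a carboxylic acid.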